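Fluorine for chlorine on the aryl ketone of compound 1

A few compounds are considered here, and "the series" means these few. Any claim that something is new, unique, unknown or untested is made for them only; others in the source may bear on it.

Measured so far:
compound 1, `COc1cc(-c2cc(/C=C/C(=O)c3ccc(Cl)c(Cl)c3)[nH]n2)cc(OC)c1OC`: > 100000 nM
compound 2, `COc1ccc(-c2cc(/C=C/C(=O)c3cc(OC)c(OC)c(OC)c3)[nH]n2)cc1OC`: 3690 nM

In a functional assay on M14 cells (Homo sapiens) for inhibition, read by sulforhodamine B assay, with a stated time of 48 h (a lower number here means a stronger inhibitor of growth, a higher number a weaker inhibitor of growth), compound 1 gives > 100000 nM, which is a limit of the assay and not a number; it sits at the limit of > 100000 nM in this assay, at which 1 of the 2 values shown sits. Compound 2 gives 3690 nM in this assay. Compound 3, `COc1cc(-c2cc(/C=C/C(=O)c3ccc(F)c(F)c3)[nH]n2)cc(OC)c1OC`, differs from compound 1 by 3,4-difluorophenyl in place of 3,4-dichlorophenyl on a carbonyl carbon. Among the measured compounds shown here, no measured step joins compound 1 and compound 3, so the expectation rests on the change alone. The step of an at least 1.6-fold lower number from compound 1 to compound 3 (0.22 log units; that floor lies within the scatter) is expected to be small, probably within the scatter. Compound 3 is estimated at 60000 nM in this assay, with a range from 8000 nM to 200000 nM, and a limit again is quite possible.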

Compound 3, concentration for total growth inhibition: 11900 nM
For compound 3 the middle estimate is 5.0-fold (0.70 log units) above the measured one, within the range that was stated.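

In this assay, 3,4-difluorophenyl in place of 3,4-dichlorophenyl on the carbonyl carbon gives an at least 8.4-fold lower number from compound 1 to compound 3 (0.92 log units; beyond the scatter). The halogen pair at this place can therefore move the read-out from a limit to a number, which no earlier comparison could show. Compound 1 gives > 100000 nM, which is a limit of the assay and not a number, so the step is a floor only.

Still open, on these data alone, is whether a plain phenyl, or a phenyl carrying an amine or a carboxylic acid, at this place would hold the read-out of compound 3. Also open, as far as these compounds go, is whether a single fluorine would do the same.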